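The compounds below may be only part of what the source reports. "The series", "measured", "known", "first", "only" and "open" are said of these compounds alone.

Measured compounds:
compound 1 `O=C(CCCCCCC(=O)Nc1ccc(Nc2nc(-c3cn[nH]c3)c3cc[nH]c3n2)cc1)NO` with 0.2 nM
compound 2 `CCCn1cc(-c2nc(Nc3ccc(NC(=O)CCCCCCC(=O)NO)cc3)nc3[nH]ccc23)cn1` with 1.6 nM
compound 3 `C=CCCn1cc(-c2nc(Nc3ccc(NC(=O)CCCCCCC(=O)NO)cc3)nc3[nH]ccc23)cn1` with 0.25 nM

In an assay on isolated protein for inhibition of protein deacetylase HDAC6 (Homo sapiens), read by fluorescence (a higher number here means a weaker inhibitor, a lower number a stronger inhibitor), compound 3 gives 0.25 nM, the second highest of the three numbers. Its nearest neighbour is compound 1, which gives 0.2 nM; the two lie within the scatter of each other, as a 1.3-fold higher number from compound 1 to compound 3 (0.10 log units; within the scatter) shows. Furthest away is compound 2, which gives 1.6 nM; that gap, a 6.4-fold lower number from compound 2 to compound 3 (0.81 log units; beyond the scatter), lies beyond the scatter.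

Compound 4 `COCCn1cc(-c2nc(Nc3ccc(NC(=O)CCCCCCC(=O)NO)cc3)nc3[nH]ccc23)cn1` has not yet been measured in this assay. It differs from compound 3 in one place: methoxy in place of vinyl on a saturated chain carbon, two bonds along the chain from an aromatic nitrogen. Within the data shown here, two measured steps bear on it. One is an 8.0-fold higher number from compound 1 to compound 2 (0.90 log units; beyond the scatter), a modest rise; the other is a 6.4-fold lower number from compound 2 to compound 3 (0.81 log units; beyond the scatter), a modest fall, which leaves compound 3 close to compound 1 again. Among the measured compounds shown here, there is no measured step in which methoxy replaces vinyl, so what this change does is not known from these compounds. The expectation is that compound 4 lands somewhere between compound 3 and compound 2, so a small rise is estimated, a 2.4-fold higher number from compound 3 to compound 4 (0.38 log units; beyond the scatter), not certainly beyond the scatter. Compound 4 is thus expected to give about 0.6 nM in this assay, with a range from 0.2 nM to 2 nM.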

Compound 4, half-maximal inhibitory concentration: 2.1 nM
Compound 4: middle estimate off by 3.5-fold (0.54 log units), on the low side; measured number above the stated range.
By their numbers in this assay, from the lowest: compounds 1 and 3 (each within the scatter of the next); then compounds 2 and 4 (each within the scatter of the next).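

In this assay, methoxy and vinyl each count 2 heavy atoms on the saturated chain carbon, yet exchanging one for the other is far from neutral (an 8.4-fold higher number from compound 3 to compound 4 (0.92 log units; beyond the scatter)), so the low number of compound 3 does not carry over to every chain of this length. Methoxy in place of methyl gives no readable difference (a 1.3-fold higher number from compound 2 to compound 4 (0.12 log units; within the scatter)), and 2-methoxyethyl in place of hydrogen on the aromatic nitrogen costs about as much as propyl does, the largest step seen at this position (an 11-fold higher number from compound 1 to compound 4 (1.02 log units; beyond the scatter)); among the three substituted compounds, compound 2 and compound 4 thus stand together, and compound 3 goes against them by staying level with the unsubstituted compound 1. Nothing available explains why the chain end matters so much here.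

From the compounds shown here alone, whether the double bond itself is what counts remains open: a but-3-yn-1-yl chain, with a triple bond at its end, could read like but-3-en-1-yl or like propyl. How a terminal hydroxyl, a terminal amine or a longer chain such as pentyl would read at this position is equally unsettled.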